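Extra piperazine methyls in the series: compound 3

This account rests on a few compounds, and the source may have more. Where it says the series, first, only, none or still open, it means among the compounds named here.

In an ADME assay on microsomes from liver (Mus musculus) for metabolic stability, read by LC-MS, with a stated time of 10 min (a lower number here means that less of the compound is left, a higher number that more of the compound is left), compound 1 (`CC(C)N1CCN(c2cccc3c2C[C@H](CN(C)[C@H]2CCCc4cccnc42)NC3)CC1`) gives 15.1% and compound 2 (`CN1CCN(c2cccc3c2C[C@H](CN(C)[C@H]2CCCc4cccnc42)NC3)CC1`) gives 17%. For the measured compounds named here, compound 2 therefore stands level with compound 1, the only other measured compound, within the scatter.

Compound 3 (`C[C@@H]1CN(c2cccc3c2C[C@H](CN(C)[C@H]2CCCc4cccnc42)NC3)C[C@H](C)N1C`) carries 3,4,5-trimethylpiperazin-1-yl in place of the 4-methylpiperazin-1-yl of compound 2, on an aromatic carbon of the shared core (3,4,5-trimethylpiperazin-1-yl in place of 4-methylpiperazin-1-yl on an aromatic carbon). Going by the values given here, one measured step bears on this change: a number 1.9 percentage points higher from compound 1 to compound 2 (within the scatter), a step that swaps an isopropyl group for a methyl group. Among the compounds with values here, that step lies within the scatter, but it gives only indirect guidance, as no measured compound carries the two further methyls of compound 3.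

No change beyond the scatter is expected in this assay, and the expected step is a number 2 percentage points higher from compound 2 to compound 3 (within the scatter). For compound 3 the estimated value is 19%, with an expected range of 9% to 35%.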

Compound 3, percent of the compound remaining: 39.6%
The estimate for compound 3 lay 20.6 percentage points below the measured number, outside the stated range (above it).
By their numbers in this assay, from the lowest: compounds 1 and 2 (each within the scatter of the next); then compound 3.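

In this assay, the group on the aromatic carbon of the shared core can move the read-out well beyond the scatter: 3,4,5-trimethylpiperazin-1-yl in place of 4-methylpiperazin-1-yl gives a number 22.6 percentage points higher from compound 2 to compound 3 (beyond the scatter), whereas changing only the group on the ring nitrogen gave a number 1.9 percentage points higher from compound 1 to compound 2 (within the scatter). In place of 4-isopropylpiperazin-1-yl, the same group gives a number 24.5 percentage points higher from compound 1 to compound 3 (beyond the scatter), which sets compound 3 clear of both earlier compounds. Nothing measured here gives a reason for this gain.

The two added ring methyls appear only together and with one set of defined stereocentres, so the contribution of each methyl and of their stereochemistry cannot be separated. Going by these compounds, whether a single added ring methyl, or a morpholine on the same aromatic carbon, would give a similar number remains open.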